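A cyclopropyl carbinol on the amide nitrogen of a lipopeptide

The compounds below may be only part of what the source reports. "The series", "measured", "known", "first", "only" and "open" are said of these compounds alone.

Among the measured compounds shown here, compound 2 `CCCCCCCCCCCC(=O)OC[C@H](CSC[C@@H](N)C(=O)NCCCC(C)(C)CO)OC(=O)CCCCCCCCCCC` gives 30700 nM in an assay on HEK293 cells for agonist activity at Toll-like receptor 2 (Homo sapiens) (on this read-out lower numbers stand for an effect already at smaller amounts and higher numbers for an effect only at larger amounts of compound), the higher of the two numbers measured so far; compound 1 `CCCCCCCCCCCC(=O)OC[C@H](CSC[C@@H](N)C(=O)N[C@@H](C)CO)OC(=O)CCCCCCCCCCC` gives 1560 nM. Compound 3 `CCCCCCCCCCCC(=O)OC[C@H](CSC[C@@H](N)C(=O)NC1(CO)CC1)OC(=O)CCCCCCCCCCC` differs from compound 2 by 1-(hydroxymethyl)cyclopropyl in place of 4-(hydroxymethyl)-4-methylpentyl on an amide-type nitrogen. For the measured compounds named here, the only measured step bearing on this change is a 20-fold higher number from compound 1 to compound 2 (1.29 log units; beyond the scatter), which accompanied the move from 1-(hydroxymethyl)ethyl to 4-(hydroxymethyl)-4-methylpentyl. For compound 3, which carries the compact 1-(hydroxymethyl)cyclopropyl, a number between the two measured values is expected, a step of an 8.8-fold lower number from compound 2 to compound 3 (0.94 log units; beyond the scatter). Compound 3 is therefore estimated at 3500 nM, with a range from 900 nM to 14000 nM.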

Compound 3, half-maximal effective concentration: 265 nM
Compound 3: the middle estimate sits 13-fold (1.12 log units) above what was measured; measured number below the stated range.
By their numbers in this assay, from the lowest: compound 3; then compound 1; then compound 2.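

In this assay, 1-(hydroxymethyl)cyclopropyl on the amide-type nitrogen gives a 120-fold lower number from compound 2 to compound 3 (2.06 log units; beyond the scatter) and also improves on 1-(hydroxymethyl)ethyl, with a 5.9-fold lower number from compound 1 to compound 3 (0.77 log units; beyond the scatter) at this position. The earlier pair showed only a loss at this nitrogen, whereas compound 3 now has the lowest number of the three, beyond the scatter against both others. Nothing available explains this gain. On these data alone, whether the three-membered ring itself is needed remains open. A 1-(hydroxymethyl)cyclobutyl or a 2-hydroxy-1,1-dimethylethyl group on the same nitrogen would address that.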